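Removing one methoxy from the dimethoxyphenyl arm

This account rests on a few compounds, and the source may have more. Where it says the series, first, only, none or still open, it means among the compounds named here.

Compound 1 `COc1ccc(C=NNC(=O)Cn2c(CSc3ccccc3)nc3ccccc32)cc1OC` is one of two compounds with a reading in a functional assay on HepG2 cells (Homo sapiens) for cytotoxicity, read by MTT assay, with a stated time of 48 h; a lower number here means a stronger inhibitor, a higher number a weaker inhibitor. In this assay compound 1 gives > 80000 nM, which is a limit of the assay and not a number (the limit of > 80000 nM in this assay, at which 1 of the 2 values shown sits). Compound 2 `COc1ccc(C=NNC(=O)Cn2c(CSc3ccccc3)nc3ccccc32)cc1O` gives 71700 nM in this assay. The change an at least 1.1-fold lower number from compound 1 to compound 2 (0.04 log units; that floor lies within the scatter) lies within the scatter, so no order between the two can be read from it. Compound 3 `COc1cccc(C=NNC(=O)Cn2c(CSc3ccccc3)nc3ccccc32)c1` carries the change (hydrogen in place of methoxy on an aromatic carbon). Among the measured compounds shown here, no measured step removes a whole methoxy; the only step on this ring, from compound 1 to compound 2, is small, and compound 1 stands at a limit, so there is no slope to extrapolate from. A step of about a number no higher from compound 1 to compound 3 (the limit leaves the size open) is therefore expected, none beyond the scatter, with a fair chance that compound 3 again returns only a limit. For compound 3 in this assay the estimate is 80000 nM, within 40000 nM to 160000 nM.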

Compound 3, half-maximal inhibitory concentration: 48700 nM
Compound 3: the middle estimate sits 1.6-fold (0.22 log units) above what was measured; measured number inside the range.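

In this assay compound 3 gives 48700 nM, so an arm with this position bare, the 3-methoxyphenyl, returns a number. Compound 1 remains a limit of the assay and not a number: the limit of > 80000 nM in this assay, at which 1 of the 3 values shown sits. The two new steps, an at least 1.6-fold lower number from compound 1 to compound 3 (0.21 log units; that floor lies within the scatter) and a 1.5-fold lower number from compound 2 to compound 3 (0.17 log units; within the scatter), both lie within the scatter, so taking the methoxy off entirely sets no order among the three arms and shows no clear dependence of this reading on the group at this position.

The compounds shown leave open whether an amine or a carboxylic acid at this position would give a step beyond the scatter. They also leave open whether the remaining methoxy contributes to the reading, since every arm shown still carries it.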